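Bromo for Cyclopropyl on the Shared Core

This account rests on a few compounds, and the source may have more. Where it says the series, first, only, none or still open, it means among the compounds named here.

Compound 1 `C[C@H]1[C@H](NCc2cc(C3CC3)cs2)C[C@H]2C[C@@H]1C2(C)C`: 25000 nM
Compound 2 `C[C@H]1[C@H](NCc2sccc2C2CCCCC2)C[C@H]2C[C@@H]1C2(C)C`: 1560 nM
Compound 3 `CCCCc1ccsc1CN[C@@H]1C[C@H]2C[C@@H]([C@H]1C)C2(C)C`: 25000 nM

In an ADME assay on MDCK cells (Canis lupus familiaris) for cytotoxicity, read by microscopy, with a stated time of 48 h (on this read-out higher numbers stand for lower toxicity in this test and lower numbers for higher toxicity in this test), compound 1 gives 25000 nM, level at the digits shown with compound 3 and together the highest of the three numbers, while compound 2 sits far lower. Compound 4 `C[C@H]1[C@H](NCc2cc(Br)cs2)C[C@H]2C[C@@H]1C2(C)C` differs from compound 1 in one place: bromo in place of cyclopropyl on an aromatic carbon. For the measured compounds named here, the only measured step, a 16-fold higher number from compound 2 to compound 3 (1.20 log units; beyond the scatter), swaps one carbon group for another on the aromatic carbon that bears a large group and so does not directly mirror a bromo entering. Since compound 1 and compound 3 already share the highest value, a step of no change at the digits printed from compound 1 to compound 4 (within the scatter) is expected, that is none beyond the scatter. Compound 4 is therefore estimated at 25000 nM, in the range 12500 nM to 50000 nM.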

Compound 4, minimum cytotoxic concentration: 6250 nM
The estimate for compound 4 lay 4.0-fold (0.60 log units) above the measured number; the measured number lies below the stated range.
By their numbers in this assay, from the lowest: compound 2; then compound 4; then compounds 1 and 3 (each within the scatter of the next).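

In this assay the swap gives a 4.0-fold lower number from compound 1 to compound 4 (0.60 log units; beyond the scatter) and so shows that this ring carbon, two ring bonds from the ring sulfur, is sensitive to what it carries, with bromo giving higher toxicity in this test than cyclopropyl. The earlier step only exchanged one carbon group for another, whereas this one puts a halogen in place of a carbon ring. Nothing measured here accounts for the shift. From the compounds shown here alone, whether a methyl, a chloro or an amine at this position would track bromo or cyclopropyl remains open.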